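The source may hold more compounds than are shown below. What is called first, only, known or untested is meant among the compounds shown, and "the series" means these compounds.

In an ADME assay on MT4 cells (Homo sapiens) for cytotoxicity, read by MTT assay, with a stated time of 4 days (on this read-out higher numbers stand for lower toxicity in this test and lower numbers for higher toxicity in this test), compound 2, `CCOC(=O)c1cnc(N2CCN(Cc3cc(F)cc(F)c3)CC2)nc1Oc1c(C)cc(-c2ccc(C#N)cc2)cc1C`, stands only at a limit of the assay: compound 2 gives > 125000 nM, a limit and not a number. Going by the values given here, the one other compound with a value, compound 1, `CCOC(=O)c1cnc(N2CCN(Cc3cccc(C(=O)OC)c3)CC2)nc1Oc1c(C)cc(-c2ccc(C#N)cc2)cc1C`, also reaches only a limit: compound 1 gives > 125000 nM. Between them lies the step that the two limits leave unreadable from compound 1 to compound 2, whose size cannot be read because both values rest on (the limit of > 125000 nM in this assay, at which 2 of the 2 values shown sit). Compound 3, `CCOC(=O)c1cnc(N2CCN(Cc3ccc(S(C)(=O)=O)cc3)CC2)nc1Oc1c(C)cc(-c2ccc(C#N)cc2)cc1C`, differs from compound 2 by 4-(methylsulfonyl)phenyl in place of 3,5-difluorophenyl on a saturated chain carbon bound to an amine nitrogen in a ring. Among the compounds with values here, the single measured step bears on this change only in that it shows no readable movement, so the step from compound 2 to compound 3 is also expected to be unreadable, with compound 3 expected to sit at or beyond the limit, an estimated step that the limit leaves unreadable from compound 2 to compound 3. Compound 3 is thus estimated to give 150000 nM, with a range from 70000 nM to 300000 nM.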

Compound 3, half-maximal cytotoxic concentration: > 125000 nM
Compound 3: only a limit was reported; the forecaster's own chance of this, stated with the estimate: 80%; the middle value is on the limit's open side.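

No new step can be read among compound 1, compound 2 and compound 3, because all their values rest on one limit: the limit of > 125000 nM in this assay, at which 3 of the 3 values shown sit.

The compounds shown leave open whether these three differ at all in this assay, and how far any of them lies past that limit.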